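A few compounds are considered here, and "the series" means these few. Any claim that something is new, unique, unknown or untested is made for them only; others in the source may bear on it.

Working notes on the series

Three compounds of the series have a number in a physicochemical assay for solubility, measured as kinetic solubility, at pH 2; on this read-out lower numbers stand for lower solubility and higher numbers for higher solubility. Compound 1 `CC(C)C(Nc1nccs1)c1ccc(-c2ccc3cccc(F)c3c2)[nH]c1=O` gives 32900 nM. Compound 2 `CC(C)[C@H](C[C@H]1CCNC1=O)c1ccc(-c2ccc3cccc(F)c3c2)[nH]c1=O` gives 38300 nM, and compound 3 `CCn1ncc2c(F)cc(-c3ccc(C(CC)(CC)c4nnc[nH]4)c(=O)[nH]3)cc21` gives 39100 nM. Compound 1 sits at the bottom of these three numbers, but its gap to compound 2 and its gap to compound 3 both fall within the scatter of repeated measurements, so the three are indistinguishable on this read-out and no order among them should be read from the figures. Among the measured compounds shown here, no pair of measured compounds differs in one place only, so no step within the measured set is available to lean on.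

Compound 4 `Cc1c[nH]c(C(c2ccc(-c3ccc4cccc(F)c4c3)[nH]c2=O)C(C)C)n1` is the next member and has not yet been run in this assay. Compared with compound 1 the change is a single one: 4-methyl-1H-imidazol-2-yl in place of (1,3-thiazol-2-yl)amino on a saturated chain carbon bound to an aromatic carbon and a saturated chain carbon. The shared core of compound 1 is kept unchanged.

For the measured compounds named here, with no measured step to calibrate against, any expectation rests only on the values of compounds 1 to 3 and the change itself. The step from compound 1 to compound 4 in this assay is expected to be a 1.8-fold higher number from compound 1 to compound 4 (0.26 log units; within the scatter), a modest rise close to the edge of the scatter rather than a large shift. Compound 4 is thus estimated at 60000 nM, with a plausible range from 30000 nM to 150000 nM.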

Compound 4, solubility: 6300 nM
Estimate against measurement, compound 4: 9.5-fold (0.98 log units) above, outside the stated range (below it).
By their numbers in this assay, from the lowest: compound 4; then compounds 1, 2 and 3 (each within the scatter of the next).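

The position on the saturated chain carbon bound to an aromatic carbon and a saturated chain carbon responds in this assay: with the shared core unchanged, 4-methyl-1H-imidazol-2-yl in place of (1,3-thiazol-2-yl)amino gives a 5.2-fold lower number from compound 1 to compound 4 (0.72 log units; beyond the scatter), a step beyond the scatter. The leaving and entering groups have the same count of heavy atoms, and each holds one five-membered aromatic ring with 2 hetero atoms, so this read-out separates two groups that match on those counts but differ in their atoms, their hydrogen-bond acceptor counts and the amino link present only in the group that leaves. No measurement available here accounts for the step.

This single step does not separate the contributions of the ring, the methyl and the amino link, and (1H-imidazol-2-yl)amino or unsubstituted 1H-imidazol-2-yl at this position would bear directly on that. Also open, going by these compounds, is how a non-aromatic group such as a dimethylamino group would read at this position, and whether the same exchange on the cores of compounds 2 and 3 would give a step of similar size.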